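Phenyl for Piperidinyl: Solubility Outlook for Compound 4

A few compounds are considered here, and "the series" means these few. Any claim that something is new, unique, unknown or untested is made for them only; others in the source may bear on it.

Of the compounds shown here, three sharing one core have been measured in a physicochemical assay for solubility, in phosphate buffer, measured as kinetic solubility, at pH 7.4; on this read-out higher numbers stand for higher solubility and lower numbers for lower solubility. Compound 1 `O=c1[nH]ccc2c(NC3CCCC3)ncnc12` gives 318000 nM. Compound 2 `N#C[C@H]1CCC[C@H]1Nc1ncnc2c(=O)[nH]ccc12` gives 104000 nM, and compound 3 `N#C[C@H]1CCC[C@H]1Nc1nc(N2CCCCC2)nc2c(=O)[nH]ccc12` gives 8600 nM. Compound 3 therefore stands lowest of the three numbers; its nearest neighbour is compound 2 and its furthest is compound 1, both gaps lying beyond the scatter.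

The two known steps are a 3.1-fold lower number from compound 1 to compound 2 (0.49 log units; beyond the scatter) and a 12-fold lower number from compound 2 to compound 3 (1.08 log units; beyond the scatter). The second of these is the one that bears on the new compound, since it concerns the same aromatic carbon between two ring nitrogen atoms.

Compound 4 `N#C[C@H]1CCC[C@H]1Nc1nc(-c2ccccc2)nc2c(=O)[nH]ccc12` differs from compound 3 in one place: phenyl in place of piperidin-1-yl on an aromatic carbon. Among the compounds with values here, no measured pair shows exactly this exchange of one six-membered ring for another at that position, so the direction can only be inferred from the fact that filling this aromatic carbon with a ring in compound 3 gave a large drop. A smaller move in the same direction is expected, a 2.5-fold lower number from compound 3 to compound 4 (0.39 log units; beyond the scatter). For compound 4 the estimated value in this assay is 3500 nM, with a likely range from 1000 nM to 12000 nM.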

Compound 4, solubility: 11000 nM
Compound 4: middle estimate off by 3.1-fold (0.50 log units), on the low side, and the stated range covers the measured number.
By their numbers in this assay, from the lowest: compounds 3 and 4 (each within the scatter of the next); then compound 2; then compound 1.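

In this assay, the exchange on this aromatic carbon between two ring nitrogen atoms gives a 1.3-fold higher number from compound 3 to compound 4 (0.11 log units; within the scatter) and so leaves phenyl and piperidin-1-yl indistinguishable here, although one ring is aromatic and of carbon only while the other is non-aromatic with 1 hetero atom. Set against hydrogen at the same carbon, phenyl gives a 9.5-fold lower number from compound 2 to compound 4 (0.98 log units; beyond the scatter) and piperidin-1-yl gives a 12-fold lower number from compound 2 to compound 3 (1.08 log units; beyond the scatter), so the lower number that comes with filling this position is not particular to piperidin-1-yl. Nothing at hand explains why the two rings read alike at this position.

The compounds shown leave open whether a smaller group such as methyl or dimethylamino, or a ring or chain carrying a carboxylic acid or a primary amine, would stay close to compound 3 and compound 4 or move towards compound 2 in this assay. They also leave open whether phenyl on this carbon would give a similar step on the core of compound 1, which has a cyclopentylamino group without the nitrile.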